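Propylamino to octylsulfanyl on the shared core: cytotoxicity notes

The source may report more compounds than this note shows. Statements on the series, on what has been measured and on what is new or still open speak of the compounds shown alone.

The series shares the core seen in compound 1 `CCCNc1nc(N)nc2c1ncn2/C=C1/CC1(CO)CO` and varies the group on one aromatic carbon. In an ADME assay on HFF cells (Homo sapiens) for cytotoxicity, with a stated time of 8 days (on this read-out lower numbers stand for higher toxicity in this test and higher numbers for lower toxicity in this test), compound 1 gives > 300000 nM, which is a limit of the test rather than a number. Compound 2 `CCCOc1nc(N)nc2c1ncn2/C=C1/CC1(CO)CO` carries propoxy in place of propylamino on an aromatic carbon, and in this assay compound 2 gives > 300000 nM, again a limit. Compound 3 `CCCSc1nc(N)nc2c1ncn2/C=C1/CC1(CO)CO` carries propylsulfanyl in place of propylamino on an aromatic carbon, and in this assay compound 3 gives > 300000 nM, also a limit. The steps a step that the two limits leave unreadable from compound 1 to compound 2, a step that the two limits leave unreadable from compound 1 to compound 3 and a step that the two limits leave unreadable from compound 2 to compound 3 cannot be read because every value sits at the limit of > 300000 nM in this assay, at which 3 of the 3 values shown sit.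

Compound 4 `CCCCCCCCSc1nc(N)nc2c1ncn2/C=C1/CC1(CO)CO` is not yet measured. It differs from compound 1 as follows: octylsulfanyl in place of propylamino on an aromatic carbon. Among the measured compounds shown here, the steps that bear on it, from compound 1 to compound 3 and from compound 2 to compound 3, put propylsulfanyl on the same carbon, but their size is unreadable. Nothing measured here fixes the effect of lengthening the chain from propyl to octyl. In this assay compound 4 is expected near 150000 nM, between 30000 nM and 400000 nM. This amounts to an expected step of an at least 2.0-fold lower number from compound 1 to compound 4 (0.30 log units; that floor lies within the scatter), with a reading at the limit about as likely as a number.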

Compound 4, half-maximal cytotoxic concentration: > 300000 nM
Compound 4: no number, only a limit; the forecaster's own chance of this, stated with the estimate: 50%; at least 2.0-fold (0.30 log units) between middle value and limit.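

In this assay compound 4 gives > 300000 nM, a limit and not a number. The steps to compound 4 from compound 1, compound 2 and compound 3 therefore cannot be read, because of where the values sit: the limit of > 300000 nM in this assay, at which 4 of the 4 values shown sit. The compounds shown leave open whether any of these groups on the aromatic carbon changes the read-out at all.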